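The source may hold more compounds than are shown below. What is called first, only, known or untested is meant among the compounds shown, and "the series" means these compounds.

Measured compounds:
- compound 1 `CC(C(=O)NCc1ccc(C(F)(F)F)nc1-c1ccccc1F)c1ccc(NS(C)(=O)=O)c(F)c1` gives 63.3 nM in an assay on CHO cells for antagonist activity at transient receptor potential cation channel subfamily V member 1 (Homo sapiens), read by FLIPR; on this read-out higher numbers stand for weaker inhibition and lower numbers for stronger inhibition
- compound 2 `CC(C(=O)NCc1ccc(C(F)(F)F)nc1-c1ccc(C(C)(C)C)cc1)c1ccc(NS(C)(=O)=O)c(F)c1` gives 0.5 nM in this assay
- compound 3 `CC(C(=O)NCc1ccc(C(F)(F)F)nc1-c1ccc(Cl)c(Cl)c1)c1ccc(NS(C)(=O)=O)c(F)c1` gives 0.9 nM in this assay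

Compound 3 stands second highest of these three numbers: its nearest neighbour is compound 2, and the gap between them, a 1.8-fold higher number from compound 2 to compound 3 (0.26 log units; within the scatter), lies within the scatter, whereas compound 1 lies far away, a 70-fold lower number from compound 1 to compound 3 (1.85 log units; beyond the scatter).

Compound 4 `COc1ccc(-c2nc(C(F)(F)F)ccc2CNC(=O)C(C)c2ccc(NS(C)(=O)=O)c(F)c2)cc1F` has not yet been measured in this assay. It differs from compound 3 in one place: 3-fluoro-4-methoxyphenyl in place of 3,4-dichlorophenyl on an aromatic carbon, that is, a 3-fluoro-4-methoxyphenyl in place of a 3,4-dichlorophenyl on an aromatic carbon next to the ring nitrogen of the shared core.

The measured steps that bear on this position are a 130-fold lower number from compound 1 to compound 2 (2.10 log units; beyond the scatter) and a 70-fold lower number from compound 1 to compound 3 (1.85 log units; beyond the scatter), both large, showing that the choice of aryl group here can shift the number strongly, while a 1.8-fold higher number from compound 2 to compound 3 (0.26 log units; within the scatter) shows two different disubstituted aryl groups giving numbers within the scatter of each other. Going by the values given here, no measured compound carries a methoxy group at this place, so the step is uncertain. A modest weakening is expected for compound 4, a 3.3-fold higher number from compound 3 to compound 4 (0.52 log units; beyond the scatter), giving an estimated value of 3 nM with a range from 0.8 nM to 15 nM.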

Compound 4, inhibition constant: 4.2 nM
For compound 4 the middle estimate is 1.4-fold (0.15 log units) below the measured one, and the stated range covers the measured number.
By their numbers in this assay, from the lowest: compounds 2 and 3 (each within the scatter of the next); then compound 4; then compound 1.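

Until now, the two substituted aryl groups in compounds 2 and 3 gave numbers within the scatter of each other, so they could have seemed interchangeable at this place on the shared core. Compound 4 shows otherwise, with a 4.7-fold higher number from compound 3 to compound 4 (0.67 log units; beyond the scatter) and an 8.4-fold higher number from compound 2 to compound 4 (0.92 log units; beyond the scatter), both modest, while a 15-fold lower number from compound 1 to compound 4 (1.18 log units; beyond the scatter) shows that 3-fluoro-4-methoxyphenyl still keeps much of the large gain over 2-fluorophenyl. Nothing in the data shown says what lies behind these differences.

This change replaces both ring substituents at once, so the compounds shown leave open how much of the step belongs to the methoxy group and how much to the fluorine; a 4-methoxyphenyl or 3-chloro-4-methoxyphenyl group could separate the two. Also open, as far as these compounds go, is how an amine such as morpholine would behave at this place.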